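This account rests on a few compounds, and the source may have more. Where it says the series, first, only, none or still open, it means among the compounds named here.

Compound 1 `COc1ccc(Nc2nccc(-c3ccncc3)n2)cc1` gives 4200 nM in a functional assay for inhibition, with Homo sapiens as the target (on this read-out lower numbers stand for stronger inhibition and higher numbers for weaker inhibition), the lowest of the two numbers shown. Compound 3 `COc1ccc(Nc2nccc(-c3ccccn3)n2)cc1` gives 8300 nM, and the step of a 2.0-fold higher number from compound 1 to compound 3 (0.30 log units; within the scatter) stays within the scatter. Compound 2 `COc1ccc(N(C)c2nccc(-c3ccncc3)n2)cc1` reaches only a limit of this assay, > 24000 nM. The step of an at least 5.7-fold higher number from compound 1 to compound 2 (0.75 log units; beyond the scatter) is beyond the scatter. Compound 4 `CCN(CC)CCCOc1ccc(Nc2nccc(-c3ccncc3)n2)cc1` differs from compound 1 by 2-(diethylamino)ethyl in place of hydrogen on a saturated chain carbon bound to an oxygen on an aromatic ring. For the measured compounds named here, neither measured step touches this place: one changes the nitrogen on the aromatic ring and the other exchanges pyridin-4-yl for pyridin-2-yl, so no step of known size bears on the new chain. With nothing pointing either way, the step of a 1.1-fold lower number from compound 1 to compound 4 (0.02 log units; within the scatter) is expected to stay within the scatter. Compound 4 is estimated at 4000 nM, between 1500 nM and 12000 nM.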

Compound 4, half-maximal inhibitory concentration: 1300 nM
Estimate against measurement, compound 4: 3.1-fold (0.49 log units) above; measured number below the stated range.
By their numbers in this assay, from the lowest: compound 4; then compounds 1 and 3 (each within the scatter of the next). At a limit, above all of these: compound 2.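

The earlier steps shown here changed only the nitrogen on the aromatic ring and the pyridinyl group, so they said nothing about the methoxy group. In this assay, replacing methoxy with 3-(diethylamino)propoxy gives a 3.2-fold lower number from compound 1 to compound 4 (0.51 log units; beyond the scatter), which shows that this place tolerates a long chain and that inhibition grows stronger with this one. Nothing measured here accounts for that gain. Going by these compounds, whether the gain comes from the chain or from its amine stays open: a plain propoxy group without the amine would separate the two, and a shorter chain carrying the same diethylamino group would test the chain length.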